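The source may report more compounds than this note shows. Statements on the series, on what has been measured and on what is new or still open speak of the compounds shown alone.

Three close relatives of one scaffold have been tested in a functional assay on the whole organism (stomach) for inhibition, with Rattus norvegicus as the target, at a dose of 100 mg/kg by the intraduodenal route; on this read-out higher numbers stand for more inhibition at the one dose given (going by the name of the read-out) and lower numbers for less inhibition. Compound 1 `C/N=C(\S)C(C)Cn1ncccc1=O` is the starting point, and in this assay compound 1 gives 50.2%. Compound 2 `C/N=C(\S)CCn1ncccc1=O` differs from compound 1 by hydrogen in place of methyl on a saturated chain carbon bound to a carbon with a double bond to nitrogen and a saturated chain carbon, and in this assay compound 2 gives 35.7%. That step is a number 14.5 percentage points lower from compound 1 to compound 2 (beyond the scatter). Compound 3 `Cc1ccc(=O)n(C(C)CC(=N)S)n1` is built on a different core; the difference between the two cores is not broken down here. In this assay compound 3 gives 32.5%. Set against compound 2, this value lies within the scatter, so no order between the two can be read from it.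

Compound 4 `Cc1ccc(=O)n(CCC(=N)S)n1` has not yet been measured. It differs from compound 3 by hydrogen in place of methyl on a saturated chain carbon bound to an aromatic nitrogen and a saturated chain carbon. For the measured compounds named here, this is the same kind of change as the one from compound 1 to compound 2, a methyl leaving and a hydrogen entering, but the surroundings are not the same: in the earlier step the carbon that loses the methyl is bound to a carbon with a double bond to nitrogen and a saturated chain carbon, whereas here it is bound to an aromatic nitrogen and a saturated chain carbon. Among the compounds shown, this change has been measured only in the step from compound 1 to compound 2, so that single measured step is the only guide. For compound 4 a step of a number 10.5 percentage points lower from compound 3 to compound 4 (beyond the scatter) in this assay is expected, taken from a number 14.5 percentage points lower from compound 1 to compound 2 (beyond the scatter) but held loosely, as the surroundings differ. Compound 4 is therefore estimated at 22%, with a range from 8% to 38%.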

Compound 4, a percentage reported as inhibition, in the whole organism at one dose (the size of the read-out at that dose, not a potency): 73.9%
Beside the measured number, compound 4's estimate is 51.9 percentage points below it; the whole stated range lies below it.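

In this assay, putting hydrogen in place of methyl on a saturated chain carbon bound to an aromatic nitrogen and a saturated chain carbon gives a number 41.4 percentage points higher from compound 3 to compound 4 (beyond the scatter). On these two cores, the same kind of swap does not carry over in size or even in direction, so a step measured on one core is a poor guide to the other: the same change on two cores in this assay, a number 14.5 percentage points lower (beyond the scatter) from compound 1 to compound 2 and a number 41.4 percentage points higher (beyond the scatter) from compound 3 to compound 4, 55.9 percentage points apart, beyond the scatter of two such steps. For the compounds shown here, this does not show why the direction reverses or which difference between the core of compound 1 and the core of compound 3 decides it, and with only one pair on each core it offers no rule for predicting the swap on a third core.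

The compounds shown leave open what a group larger than methyl, such as an ethyl or a phenyl, would do on that saturated chain carbon on either core, and whether a longer chain would keep the high value of compound 4 at 73.9%. They also leave open whether the order seen at this one dose would hold at other doses, since a single-dose percentage is not a measure of potency.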